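A few compounds are considered here, and "the series" means these few. Any claim that something is new, unique, unknown or untested is made for them only; others in the source may bear on it.

Compound 1 `CCNc1ncnc2c1ncn2Cc1ccccc1F` stands lowest of the two numbers obtained in a functional assay on the whole organism with Rattus norvegicus as the target, in the maximal electroshock model (a lower number here means that less compound is needed, a higher number that more compound is needed for the effect), where compound 1 gives 4.9 mg/kg. For the measured compounds named here, its nearest neighbour is compound 2 `CN(C)c1ncnc2c1ncn2Cc1ccccc1`, which in this assay gives 6 mg/kg; the two values lie within the usual scatter of each other and so show no difference between the compounds. Compound 3 `CN(C=O)c1ncnc2c1ncn2Cc1ccccc1F` is the compound not yet measured. It differs from compound 1 in one place: formyl(methyl)amino in place of ethylamino on an aromatic carbon. The group that leaves carries one hydrogen-bond donor, the group that enters none, while each carries one hydrogen-bond acceptor. Going by the values given here, no measured pair among the compounds at hand isolates this change, so no earlier step can guide the size of its effect. Because compound 2 gives 6 mg/kg while also lacking a hydrogen-bond donor, the loss of the donor alone is not expected to move the number far; the estimated step in this assay is a small rise, close to the scatter. Compound 3 is therefore expected in this assay at 8 mg/kg, with a range from 3 mg/kg to 22 mg/kg. The expected change a 1.6-fold higher number from compound 1 to compound 3 (0.21 log units; within the scatter) is modest and upward.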

Compound 3, dose for half-maximal effect: 11 mg/kg
The estimate for compound 3 lay 1.4-fold (0.14 log units) below the measured number, within the range that was stated.
By their numbers in this assay, from the lowest: compounds 1, 2 and 3 (each within the scatter of the next, the first and the last beyond it).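

For the compounds shown here, on an aromatic carbon of the shared core, formyl(methyl)amino in place of ethylamino gives in this assay a 2.2-fold higher number from compound 1 to compound 3 (0.35 log units; beyond the scatter), the only step here that isolates a change at this position. This shows that the number responds to the group at this carbon, although the step is modest and compound 3 still gives a value in the same low range at 11 mg/kg. No measurement at hand explains the rise, and this single exchange removes the hydrogen-bond donor and brings in the carbonyl together.

The compounds shown leave open what each of those two differences contributes alone: an acetylamino group, which keeps the amide hydrogen alongside a carbonyl, and a dimethylamino group, which has no amide hydrogen and no carbonyl, would pull them apart on the core of compound 1. Also open, from the compounds shown here alone, is how far the number would move with a longer chain such as propylamino or a cyclic amine such as morpholine at this carbon, and whether the same exchange gives a similar step on a core without the fluorine.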